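Swapping the aryl group on a carbon double-bonded to nitrogen

The source may report more compounds than this note shows. Statements on the series, on what has been measured and on what is new or still open speak of the compounds shown alone.

Of the compounds shown here, three have been measured in a functional assay on the whole organism (strain albino) with Rattus norvegicus as the target, in the maximal electroshock model, with a stated time of 1 h, at a dose of 30 mg/kg by the intraperitoneal route; a lower number here means less inhibition, a higher number more inhibition at the dose given (going by the name of the read-out). Compound 1 `Cc1nc2ccccc2c(=O)n1NCc1nnc(/N=C/c2ccc(N(C)C)cc2)s1` gives 50%. Compound 2 `Cc1nc2ccc(Br)cc2c(=O)n1NCc1nnc(/N=C/c2ccc(N(C)C)cc2)s1`, which carries a bromo in place of hydrogen on an aromatic carbon, gives 50%; that step, no change at the digits printed from compound 1 to compound 2 (within the scatter), stays within the scatter. Compound 3 `Cc1nc2ccc(Br)cc2c(=O)n1NCc1nnc(N2C(=O)CSC2c2ccc(N(C)C)cc2)s1` gives 60%. Compound 2 thus stands level with compound 1 at the digits shown, the two together being the lowest of the three numbers, while the gap to compound 3 also lies within the scatter.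

Compound 4 `COc1cc(/C=N/c2nnc(CNn3c(C)nc4ccc(Br)cc4c3=O)s2)ccc1O` has not been measured. It differs from compound 2 in one place: 4-hydroxy-3-methoxyphenyl in place of 4-(dimethylamino)phenyl on a carbon with a double bond to nitrogen. Among the compounds with values here, the only measured single step, from compound 1 to compound 2, concerns a bromo on an aromatic carbon of the shared core and not the group on the carbon with a double bond to nitrogen, so no measured step bears directly on this change. Within the data shown here, compound 3 alters that same part of the molecule, but in more than one place, so its value shows only that such a change stayed within the scatter. On that footing no step beyond the scatter is expected in this assay. Compound 4 is expected to show a step of no change at the digits printed from compound 2 to compound 4 (within the scatter). Compound 4 is estimated to give 50%, ranging from 30% to 70%.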

Compound 4, a percentage reported as inhibition, in the whole organism at one dose (the size of the read-out at that dose, not a potency): 50%
The estimate for compound 4 equals the measured number at the digits printed; the range from low to high includes it.
By their numbers in this assay, from the lowest: compounds 1, 2, 4 and 3 (each within the scatter of the next).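

In this assay, within the data shown here, replacing 4-(dimethylamino)phenyl with 4-hydroxy-3-methoxyphenyl on a carbon with a double bond to nitrogen gives no change at the digits printed from compound 2 to compound 4 (within the scatter), and this is the first single change read at this position, as the earlier step concerned a bromo on the shared core. The two groups have the same number of heavy atoms but differ in make-up: 4-(dimethylamino)phenyl has 0 hydrogen-bond donors and 1 hydrogen-bond acceptor, whereas 4-hydroxy-3-methoxyphenyl has 1 hydrogen-bond donor and 2 hydrogen-bond acceptors, and this difference does not separate them in this read-out at the single dose given. No measurement available here offers an explanation for this outcome.

On these data alone, it remains open whether a plain phenyl, or a phenyl carrying a carboxylic acid, on this carbon would give a step beyond the scatter. As far as these compounds go, it is also open whether the same swap would read alike on the core of compound 1, which lacks the bromo, and whether the two groups would stay level at other doses.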